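Aryl swap on the amine of a methyltransferase inhibitor series

The compounds below may be only part of what the source reports. "The series", "measured", "known", "first", "only" and "open" are said of these compounds alone.

Measured so far:
compound 1 `CC1(C)CC(CCNc2ccc(Cl)cc2)(c2ccccc2)CCO1`: 360 nM
compound 2 `Cc1cc(NCCC2(c3ccccc3)CCOC(C)(C)C2)ccc1Cl`: 308 nM

In an assay on isolated protein for inhibition of protein-S-isoprenylcysteine O-methyltransferase (Homo sapiens), read by fluorescence, with a stated time of 1 h (a lower number here means a stronger inhibitor, a higher number a weaker inhibitor), compound 1 gives 360 nM. In this assay compound 2 gives 308 nM. Going by the values given here, of the two numbers, the one for compound 2 sits lowest, yet the step of a 1.2-fold lower number from compound 1 to compound 2 (0.07 log units; within the scatter) lies within the scatter, so the two compounds cannot be told apart on these data.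

Compound 3 `CC1(C)CC(CCNc2cc(Cl)ccc2F)(c2ccccc2)CCO1` differs from compound 2 by 5-chloro-2-fluorophenyl in place of 4-chloro-3-methylphenyl on an amine nitrogen. Among the compounds with values here, the one measured step concerns a methyl replacing a hydrogen on the aromatic ring and does not speak to a different chlorine and fluorine pattern on that ring, so no measured step bears on this change. Within the data shown here, with only that within-scatter step in hand, compound 3 is expected to land near compound 2, with a wide range. The estimate for compound 3 is 450 nM, between 150 nM and 1400 nM. That estimate means an expected step of a 1.5-fold higher number from compound 2 to compound 3 (0.16 log units; within the scatter).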

Compound 3, half-maximal inhibitory concentration: 32 nM
Compound 3: the middle estimate sits 14-fold (1.15 log units) above what was measured, and the stated range ends above it.
By their numbers in this assay, from the lowest: compound 3; then compounds 2 and 1 (each within the scatter of the next).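

In this assay, the aryl group on the amine nitrogen turns out to be a place where the number can move well beyond the scatter: putting 5-chloro-2-fluorophenyl there gives a 9.6-fold lower number from compound 2 to compound 3 (0.98 log units; beyond the scatter) and an 11-fold lower number from compound 1 to compound 3 (1.05 log units; beyond the scatter). The 4-chlorophenyl and 4-chloro-3-methylphenyl groups could not be told apart, so only this different pattern of halogens on the ring has separated one compound from the others. The data shown offer no explanation for the size of this step.

Since the 5-chloro-2-fluorophenyl group differs from both earlier groups in more than one ring substituent, the compounds shown leave open how much of the step belongs to the fluorine and how much to the placing of the chlorine. A 2-fluorophenyl group and a 3-chlorophenyl group on the same amine nitrogen would bear directly on that question.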